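This account rests on a few compounds, and the source may have more. Where it says the series, first, only, none or still open, it means among the compounds named here.

Three compounds share one core and differ only in the group on the distant aromatic ring: compound 1 `COC(=O)CC/C(C)=C/Cc1c(OC)c(C)c2c(c1OCC#CCN1CCN(c3ccc(C)cc3)CC1)C(=O)OC2`, compound 2 `COC(=O)CC/C(C)=C/Cc1c(OC)c(C)c2c(c1OCC#CCN1CCN(c3ccc(C#N)cc3)CC1)C(=O)OC2` and compound 3 `COC(=O)CC/C(C)=C/Cc1c(OC)c(C)c2c(c1OCC#CCN1CCN(c3ccc(O)cc3)CC1)C(=O)OC2`. In a functional assay on MDA-MB-231 cells (Homo sapiens) for inhibition, read by sulforhodamine B assay (a higher number here means a weaker inhibitor, a lower number a stronger inhibitor), compound 1 gives > 50000 nM, which is a limit of the assay rather than a number. Compound 2 gives > 50000 nM in this assay, also a limit. Compound 3 gives > 50000 nM in this assay, again only a limit. The three steps among them, a step that the two limits leave unreadable from compound 1 to compound 2, a step that the two limits leave unreadable from compound 1 to compound 3 and a step that the two limits leave unreadable from compound 2 to compound 3, therefore stay unreadable because of the limit of > 50000 nM in this assay, at which 3 of the 3 values shown sit.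

Compound 4 `COC(=O)CC/C(C)=C/Cc1c(OC)c(C)c2c(c1OCC#CCN1CCN(c3ccccc3F)CC1)C(=O)OC2` has not yet been measured. It differs from compound 3 by 2-fluorophenyl in place of 4-hydroxyphenyl on an amine nitrogen in a ring. Among the measured compounds shown here, no measured step bears on this change, since every value so far sits at the same limit and nothing shows whether any group on that ring moves the read-out at all. For the measured compounds named here, with no measured step to lean on, the expectation for compound 4 is that it behaves like the three measured compounds, and the step from compound 3 is expected to be a step that the limit leaves unreadable from compound 3 to compound 4. The estimate for compound 4 in this assay is 60000 nM, with a range from 15000 nM to 250000 nM, and most likely the assay will again report only a limit.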

Compound 4, half-maximal inhibitory concentration: > 50000 nM
Compound 4 was reported as a limit (the forecaster's own chance of this, stated with the estimate: 85%); the middle value does not contradict the limit.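

Among the compounds shown here, compound 4 joins compound 1, compound 2 and compound 3 in giving only a limit in this assay and no step between any of them can be read, because all four share the same limit: the limit of > 50000 nM in this assay, at which 4 of the 4 values shown sit.

Going by these compounds, what stays open is whether changing the aromatic group on the ring nitrogen alters the read-out at all, and what the real half-maximal inhibitory concentration of each compound is.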